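A few compounds are considered here, and "the series" means these few. Any claim that something is new, unique, unknown or untested is made for them only; others in the source may bear on it.

Measured compounds:
compound 1 `S=C(Nc1cccnc1)NC1CCN(c2cc(Cl)ccn2)CC1`: 2100 nM
compound 2 `S=C(Nc1cccnc1)NC1CCN(c2cc(OCC3CC3)ccn2)CC1`: 4700 nM

Of the compounds shown here, two have been measured in an assay on membranes from brain for binding affinity to Lysophosphatidylserine lipase ABHD12 (Mus musculus), read by fluorescence, with a stated time of 20 min; on this read-out lower numbers stand for stronger inhibition and higher numbers for weaker inhibition. Compound 1 `S=C(Nc1cccnc1)NC1CCN(c2cc(Cl)ccn2)CC1` gives 2100 nM in this assay, and compound 2 `S=C(Nc1cccnc1)NC1CCN(c2cc(OCC3CC3)ccn2)CC1` gives 4700 nM. Going by the values given here, compound 2 therefore stands at the higher of the two numbers, with compound 1 as its only and nearest neighbour; the single step between them, a 2.2-fold higher number from compound 1 to compound 2 (0.35 log units; beyond the scatter), came with cyclopropylmethoxy in place of chloro on an aromatic carbon. Compound 3 `S=C(Nc1cccnc1)NC1CCN(c2cc(Oc3ccccc3)ccn2)CC1` has not yet been measured. It differs from compound 2 by phenyl in place of cyclopropylmethyl on an oxygen on an aromatic ring; read one bond further out, cyclopropylmethoxy becomes phenoxy. Among the compounds with values here, no measured step alters the group on this oxygen, so the only step at hand bears on it indirectly, and that step was modest. Compound 3 is expected to show a step of a 1.0-fold lower number from compound 2 to compound 3 (0.02 log units; within the scatter) in this assay, which is no change beyond the scatter in either direction. The estimate for compound 3 in this assay is 4500 nM, with a range from 1500 nM to 14000 nM.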

Compound 3, half-maximal inhibitory concentration: 1900 nM
Compound 3: middle estimate off by 2.4-fold (0.37 log units), on the high side, and the stated range covers the measured number.
By their numbers in this assay, from the lowest: compounds 3 and 1 (each within the scatter of the next); then compound 2.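

In this assay, the group on the oxygen proves to count on its own: phenyl in place of cyclopropylmethyl gives a 2.5-fold lower number from compound 2 to compound 3 (0.39 log units; beyond the scatter) and so moves the number beyond the scatter, though only modestly, which the earlier pair could not show because it exchanged chloro for the whole cyclopropylmethoxy group. Set against chloro, phenoxy gives a 1.1-fold lower number from compound 1 to compound 3 (0.04 log units; within the scatter) on the same aromatic carbon, so the higher number of compound 2 does not follow from having an oxygen at this place, since it appears with cyclopropylmethoxy and not with phenoxy. Nothing available explains why these two groups on the oxygen read differently.

Open, going by these compounds, is whether any group at this aromatic carbon, such as an amine, a carboxylic acid, a benzyloxy group or a phenoxy carrying a fluorine, would give a number clearly lower than those of compound 1 and compound 3. On these data alone, all three compounds also share one core, so it remains open whether the difference between phenoxy and cyclopropylmethoxy would hold on any other.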